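Side-chain variation at the oxygen on the core of compound 1

A few compounds are considered here, and "the series" means these few. Any claim that something is new, unique, unknown or untested is made for them only; others in the source may bear on it.

Measured so far in a functional assay on DU-145 cells (Homo sapiens) for cytotoxicity, read by MTT assay; on this read-out higher numbers stand for weaker inhibition and lower numbers for stronger inhibition:
- compound 1, `CC(C)=CC[C@@H](OC[C@@H](C)O)C1=CC(=O)c2c(O)ccc(O)c2C1=O`: 14300 nM
- compound 2, `CCCCC(CC(=O)O[C@H](CC=C(C)C)C1=CC(=O)c2c(O)ccc(O)c2C1=O)OC(C)=O`: 67700 nM
- compound 3, `CC(C)=CC[C@@H](OC(=O)CC(O)c1ccccc1)C1=CC(=O)c2c(O)ccc(O)c2C1=O`: 17000 nM

Compound 1 holds the lowest number of the three. Compound 3 sits close to it, the gap between the two lying within the scatter, so no order between compound 1 and compound 3 can be claimed. For the measured compounds named here, compound 2 stands clearly apart, with the higher number, and the single measured step, a 4.0-fold lower number from compound 2 to compound 3 (0.60 log units; beyond the scatter), shows that the group on the saturated chain carbon bound to the carbonyl carbon can move the read-out by a modest amount.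

Compound 4, `CC[C@@](C)(O)CC(=O)O[C@H](CC=C(C)C)C1=CC(=O)c2c(O)ccc(O)c2C1=O`, differs from compound 1 as follows: (2-hydroxy-2-methylbutyl)carbonyl in place of 2-hydroxypropyl on an oxygen on a saturated carbon. This change is not the one covered by the measured step, but the step from compound 2 to compound 3 indicates that a chain carrying a hydroxyl next to the carbonyl-bearing side chain lands near compound 1. Compound 4 carries such a chain, so no step beyond the scatter is expected in this assay; if anything a slightly higher number is expected, a 1.4-fold higher number from compound 1 to compound 4 (0.15 log units; within the scatter). The estimate for compound 4 is therefore 20000 nM, with a range from 8000 nM to 50000 nM.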

Compound 4, half-maximal inhibitory concentration: 12700 nM
For compound 4 the middle estimate is 1.6-fold (0.20 log units) above the measured one; the range from low to high includes it.
By their numbers in this assay, from the lowest: compounds 4, 1 and 3 (each within the scatter of the next); then compound 2.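

Working notes on the side chain at the oxygen on a saturated carbon. In this assay, (2-hydroxy-2-methylbutyl)carbonyl in place of 2-hydroxypropyl gives no step beyond the scatter (a 1.1-fold lower number from compound 1 to compound 4 (0.05 log units; within the scatter)), so this position accepts the entering carbonyl and the larger chain with no measurable cost in this read-out. On the saturated chain carbon bound to a carbonyl carbon, 1-hydroxy-1-methylpropyl and hydroxy(phenyl)methyl cannot be told apart (a 1.3-fold lower number from compound 3 to compound 4 (0.13 log units; within the scatter)), while the exchange of 1-acetoxypentyl for 1-hydroxy-1-methylpropyl gives a modest step (a 5.3-fold lower number from compound 2 to compound 4 (0.73 log units; beyond the scatter)), which leaves compound 2 as the only one of the four standing apart. No supporting measurement bears on the reason for these results.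

Compound 2 differs from compound 3 and compound 4 in both its acetoxy group and its longer chain, so a 1-hydroxypentyl group would be needed to show which of the two goes with the higher number. From the compounds shown here alone, whether the hydroxyl on these side chains can give way to an amine or a carboxylic acid without a step beyond the scatter also remains open.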